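From Carbamoyl to Cyano: Expecting Compound 4

This account rests on a few compounds, and the source may have more. Where it says the series, first, only, none or still open, it means among the compounds named here.

Compound 1 `COCc1ccccc1C1CCc2nc[nH]c2C1`: > 10000 nM; > 10000 nM (2 entries)
Compound 2 `Fc1ccccc1C1Cc2nccn2C1`: 301 nM
Compound 3 `NC(=O)c1ccccc1C1Cc2nccn2C1`: "not determined" (no result reported)

In a functional assay on CHO cells for agonist activity at Alpha-1D adrenergic receptor (Homo sapiens), read by FLIPR and calcium flux (a lower number here means that less compound is needed, a higher number that more compound is needed for the effect), compound 1 gives only a limit, > 10000 nM; > 10000 nM (2 entries), not a number. Compound 2 gives 301 nM in this assay. Going by these compounds, compound 3 has no single number in this assay, only an entry without a result, so its standing is unknown. Compound 4 `N#Cc1ccccc1C1Cc2nccn2C1` differs from compound 3 by cyano in place of carbamoyl on an aromatic carbon. For the measured compounds named here, no measured pair shows what this change does, so the size of the step cannot be judged from the data; compound 2, built on the same core, shows that a small group in this position allows activity. Compound 4 is therefore expected near 600 nM, with a wide range from 100 nM to 5000 nM.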

Compound 4, half-maximal effective concentration: > 10000 nM
Compound 4 ended at the assay's limit; the forecaster's own chance of this, stated with the estimate: 25%; at least 16-fold (1.22 log units) between middle value and limit.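

In this assay, cyano in place of fluoro on the shared core gives an at least 33-fold higher number from compound 2 to compound 4 (1.52 log units; beyond the scatter). Activity at this position therefore depends on which group sits there, not merely on the presence of a group. The value of compound 4 is a limit, so the full size of this step stays unknown: the limit of > 10000 nM in this assay, at which 1 of the 4 values shown sits.

Compound 3 has no single number, and the step from carbamoyl to cyano cannot be read. Going by these compounds, whether an amine or a carboxylic acid at this position would give a lower number than compound 4 remains open.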